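Swapping the furan for a chlorophenyl on the acyl arm

The source may hold more compounds than are shown below. What is called first, only, known or untested is meant among the compounds shown, and "the series" means these compounds.

Compound 1 `CC1(C)S[C@@H]2/C(=C\C(=O)c3ccco3)C(=O)N2[C@H]1C(=O)OC(c1ccccc1)c1ccccc1` is tested in a functional assay on A-375 cells (Homo sapiens) for cytotoxicity, read by MTT assay, with a stated time of 48 h (on this read-out lower numbers stand for stronger inhibition and higher numbers for weaker inhibition), and gives 26000 nM. Going by the values given here, only one other number sits beside it: compound 3 `CC1(C)S[C@@H]2/C(=C\C(=O)c3ccc(F)cc3)C(=O)N2[C@H]1C(=O)OC(c1ccccc1)c1ccccc1` gives 17800 nM in this assay, and the step of a 1.5-fold lower number from compound 1 to compound 3 (0.16 log units; within the scatter) keeps the two within the scatter of each other. Compound 2 `CC1(C)S[C@@H]2C/C(=C\C(=O)c3ccccc3)C(=O)N2[C@H]1C(=O)OC(c1ccccc1)c1ccccc1` gives a limit of > 100000 nM in this assay. Compound 4 `CC1(C)S[C@@H]2/C(=C\C(=O)c3ccc(Cl)cc3)C(=O)N2[C@H]1C(=O)OC(c1ccccc1)c1ccccc1` differs from compound 1 in one place: 4-chlorophenyl in place of furan-2-yl on a carbonyl carbon. Among the compounds with values here, the one measured step that bears on this exchange, from compound 1 to compound 3, replaced the same furan-2-yl with a 4-fluorophenyl and stayed within the scatter. A comparable outcome is expected here, so the estimated step of a 1.7-fold lower number from compound 1 to compound 4 (0.24 log units; within the scatter) should not reach beyond the scatter. Compound 4 is therefore estimated at 15000 nM, with a likely range from 6000 nM to 40000 nM.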

Compound 4, half-maximal inhibitory concentration: 48600 nM
Compound 4: middle estimate off by 3.2-fold (0.51 log units), on the low side, outside the stated range (above it).
By their numbers in this assay, from the lowest: compounds 3, 1 and 4 (each within the scatter of the next, the first and the last beyond it). At a limit, above all of these: compound 2.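

Going by these compounds alone, the exchange of one halogen for another on the aryl ring is the first change here to pass the scatter: chloro in place of fluoro gives a 2.7-fold higher number from compound 3 to compound 4 (0.44 log units; beyond the scatter), a modest step. Measured against the furan-2-yl, the 4-chlorophenyl gives a 1.9-fold higher number from compound 1 to compound 4 (0.27 log units; within the scatter), so neither halogenated ring separates clearly from compound 1. Nothing measured here accounts for the gap between the two halogens.

On these data alone, it remains open whether a bromo, a methoxy or an amine in place of the halogen on the same ring would give a number near compound 3 or near compound 4.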